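The compounds below may be only part of what the source reports. "The series", "measured", "known", "first", "only" and "open" are said of these compounds alone.

Measured compounds: compound 1 `CCCNc1ccc(NC(=O)c2cc(Cl)ccc2O)c(Cl)c1`, which in an ADME assay on A549 cells (Homo sapiens) for cytotoxicity, read by resazurin assay, with a stated time of 48 h (a higher number here means that more compound is tolerated, a lower number that less compound is tolerated), gives 22500 nM; compound 2 `CC(C)CNc1ccc(NC(=O)c2cc(Cl)ccc2O)c(Cl)c1`, which in this assay gives 60000 nM; compound 3 `CC(CCO)Nc1ccc(NC(=O)c2cc(Cl)ccc2O)c(Cl)c1`, which in this assay gives 200000 nM.

Compound 2 and compound 1 differ by hydrogen in place of methyl on a saturated chain carbon bound to two saturated chain carbons, and in this assay this gives a 2.7-fold lower number from compound 2 to compound 1 (0.43 log units; beyond the scatter). Compound 3 differs from compound 2 by 3-hydroxy-1-methylpropyl in place of isobutyl on a nitrogen on an aromatic ring, with a 3.3-fold higher number from compound 2 to compound 3 (0.52 log units; beyond the scatter), and from compound 1 by an 8.9-fold higher number from compound 1 to compound 3 (0.95 log units; beyond the scatter); compound 3 stands highest of the three, with both steps to it beyond the scatter.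

Compound 4 `O=C(Nc1ccc(NCCCO)cc1Cl)c1cc(Cl)ccc1O` has not yet been measured in this assay. It differs from compound 3 by hydrogen in place of methyl on a saturated chain carbon bound to a nitrogen on an aromatic ring and a saturated chain carbon. The same kind of change, but not the same, was made from compound 2 to compound 1: there the place was on a saturated chain carbon bound to two saturated chain carbons, whereas here it is on a saturated chain carbon bound to a nitrogen on an aromatic ring and a saturated chain carbon. Going by the values given here, only that one earlier pair is available, so the expectation rests on it alone. Compound 4 is estimated at 100000 nM, a step of a 2.0-fold lower number from compound 3 to compound 4 (0.30 log units; within the scatter) in this assay, expected because compound 2 to compound 1 showed a 2.7-fold lower number from compound 2 to compound 1 (0.43 log units; beyond the scatter), with a range of 40000 nM to 250000 nM.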

Compound 4, half-maximal cytotoxic concentration: 106000 nM
The estimate for compound 4 lay 1.1-fold (0.03 log units) below the measured number, within the range that was stated.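

In this assay, hydrogen in place of methyl on the chain gives a 1.9-fold lower number from compound 3 to compound 4 (0.28 log units; within the scatter), and this step agrees with the earlier one: the same change on two cores in this assay, a 2.7-fold lower number (0.43 log units; beyond the scatter) from compound 2 to compound 1 and a 1.9-fold lower number (0.28 log units; within the scatter) from compound 3 to compound 4, 1.4-fold (0.15 log units) apart, within the scatter of two such steps

Going by these compounds alone, the change can therefore be carried between these two cores without a readable difference in its size, but this rests on only two pairs, and the step on the core of compound 3 does not by itself pass the scatter, so it does not establish a drop on that core or show that the result would hold on a further core. The other new steps give a 1.8-fold higher number from compound 2 to compound 4 (0.25 log units; within the scatter), still within the scatter, so 2-hydroxyethyl and isopropyl at that place cannot be told apart here, and a 4.7-fold higher number from compound 1 to compound 4 (0.67 log units; beyond the scatter), beyond the scatter, for hydroxy in place of hydrogen on the chain.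

The compounds shown leave open how a longer chain carrying the hydroxy would read. They also leave open whether an amine or a carboxylic acid in place of the hydroxy would follow compound 4.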